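Methylation of the ring nitrogen in an indazole-type compound

The compounds below may be only part of what the source reports. "The series", "measured", "known", "first", "only" and "open" are said of these compounds alone.

Compound 1 `Cc1cc2[nH]nc(N)c2c(N2CCCCC2)n1` was tested in an assay on isolated protein for inhibition of ribosomal protein S6 kinase alpha-1 (Homo sapiens), read by mobility shift assay, tested at 30 uM (a higher number here means more inhibition at the concentration tested (going by the name of the read-out), a lower number less inhibition), where compound 1 gives 46%. Compound 2 `CC(=O)Nc1nn(C)c2cc(-c3ccc(N4CCN(C)CC4)cc3)[nH]c(=O)c12` shares no single-point relationship with it; in this assay compound 2 gives 16%, a number below that of compound 1 and outside the usual scatter. Compound 1 therefore stands highest of the two numbers available.

The next compound, compound 3 `Cc1cc2c(c(N)nn2C)c(N2CCCCC2)n1`, differs from compound 1 in one place: methyl in place of hydrogen on an aromatic nitrogen. Within the data shown here, no measured pair in this set shows such a change, so its effect cannot be read from the data. The present account expects the step from compound 1 to compound 3 to be a modest decrease, probably at or a little beyond the scatter, with a number 16 percentage points lower from compound 1 to compound 3 (beyond the scatter) as the estimated size. Compound 3 is accordingly expected to give about 30%, with a likely range from 10% to 55%.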

Compound 3, a percentage reported as inhibition, at one concentration (the size of the read-out at that concentration, not a potency): 23%
For compound 3 the middle estimate is 7 percentage points above the measured one; the measured number falls inside the stated range.
By their numbers in this assay, from the lowest: compounds 2 and 3 (each within the scatter of the next); then compound 1.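

In this assay, the step at this position is a number 23 percentage points lower from compound 1 to compound 3 (beyond the scatter), with methyl in place of hydrogen on an aromatic nitrogen. Among these compounds, this is the first change in the set that can be read at a single place, and it shows that adding one carbon on this nitrogen of the shared core is not neutral in this assay: the lower number lies beyond the usual scatter. Nothing measured here bears on why the number falls.

On these data alone, only hydrogen and methyl appear on this nitrogen, so it remains open whether ethyl, a longer chain or an acetyl group there would lower the number further or raise it again. As far as these compounds go, it also remains open whether the methyl step would keep its size if the amino group of the shared core gave way to an acetylamino group.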